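Swapping the Pendant Aryl Ring: Expected Cytotoxicity of Compound 4

The source may report more compounds than this note shows. Statements on the series, on what has been measured and on what is new or still open speak of the compounds shown alone.

Measured so far:
compound 1 `Cc1ccccc1-c1cc(C)c(Nc2ccnc(Nc3ccc(C#N)cc3)n2)c(C)c1` gives 3820 nM in an ADME assay on MT4 cells (Homo sapiens) for cytotoxicity, read by MTT assay, with a stated time of 4 days; on this read-out higher numbers stand for lower toxicity in this test and lower numbers for higher toxicity in this test
compound 2 `COc1cccc(-c2cc(C)c(Nc3ccnc(Nc4ccc(C#N)cc4)n3)c(C)c2)c1` gives 2990 nM
compound 3 `Cc1cc(-c2ccc(C#N)cc2)cc(C)c1Nc1ccnc(Nc2ccc(C#N)cc2)n1` gives 2080 nM

The three compounds share one core and differ only in the aryl group carried on one aromatic carbon of that core. Compound 3 gives the lowest of the three numbers, but its neighbours sit close by: the step of a 1.4-fold lower number from compound 2 to compound 3 (0.16 log units; within the scatter) and the step of a 1.8-fold lower number from compound 1 to compound 3 (0.26 log units; within the scatter) both fall within the scatter, as does the step of a 1.3-fold lower number from compound 1 to compound 2 (0.11 log units; within the scatter). The three aryl groups tried so far therefore cannot be told apart on this read-out.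

Compound 4 `Cc1cc(-c2cccc(C(F)(F)F)c2)cc(C)c1Nc1ccnc(Nc2ccc(C#N)cc2)n1` is the next member of the set. Relative to compound 3 the change is 3-(trifluoromethyl)phenyl in place of 4-cyanophenyl on an aromatic carbon. Going by the values given here, the steps that bear on this change are the ones that also exchanged the group on this same aromatic carbon, namely a 1.8-fold lower number from compound 1 to compound 3 (0.26 log units; within the scatter), a 1.4-fold lower number from compound 2 to compound 3 (0.16 log units; within the scatter) and a 1.3-fold lower number from compound 1 to compound 2 (0.11 log units; within the scatter), and none of them moved the number beyond the scatter. The new group is therefore expected to leave the number near where compound 3 sits, with no step beyond the scatter, so the expected step is a 1.3-fold higher number from compound 3 to compound 4 (0.13 log units; within the scatter). Compound 4 is estimated at 2800 nM, within a range from 1400 nM to 5600 nM.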

Compound 4, half-maximal cytotoxic concentration: 4030 nM
Beside the measured number, compound 4's estimate is 1.4-fold (0.16 log units) below it, and the stated range covers the measured number.
By their numbers in this assay, from the lowest: compounds 3, 2, 1 and 4 (each within the scatter of the next).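

In this assay, trading 4-cyanophenyl for 3-(trifluoromethyl)phenyl gives a 1.9-fold higher number from compound 3 to compound 4 (0.29 log units; within the scatter), and the two other new comparisons, a 1.3-fold higher number from compound 2 to compound 4 (0.13 log units; within the scatter) and a 1.1-fold higher number from compound 1 to compound 4 (0.02 log units; within the scatter), also stay inside the scatter. This extends the flat picture on this aromatic carbon to a fourth aryl group, one that brings fluorine atoms and lacks the hydrogen-bond acceptor counted for 4-cyanophenyl, yet the four compounds still cannot be told apart on this read-out. No supporting measurement is available to explain this lack of separation, so the result describes what was seen without giving a reason for it.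

As far as these compounds go, all four groups are aryl rings carrying a small substituent, so it remains open whether a ring bearing a carboxylic acid or an amine, or a chain such as hexyl in place of the ring, would move the number beyond the scatter. The rest of the core is the same throughout, so these compounds also say nothing about how changes elsewhere, such as replacing either methyl group on the central ring with chlorine, would behave.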